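Iodo addition on the pendant phenyl of a benzothiazolyl-amino series

This account rests on a few compounds, and the source may have more. Where it says the series, first, only, none or still open, it means among the compounds named here.

Compound 2 `COc1ccc2nc(NC(c3cn(-c4ccccc4)nc3-c3ccccc3)c3c(O)ccc4ccccc34)sc2c1` gives 40800 nM in a functional assay on MCF7 cells (Homo sapiens) for antiproliferative activity, read by MTT assay, with a stated time of 48 h; on this read-out higher numbers stand for weaker inhibition and lower numbers for stronger inhibition. Compound 1 `COc1ccc2nc(NC(c3cn(-c4ccccc4)nc3-c3cccc(I)c3)c3c(O)ccc4ccccc34)sc2c1` carries the change (iodo in place of hydrogen on an aromatic carbon), and in this assay compound 1 gives 20000 nM; the step of a 2.0-fold lower number from compound 2 to compound 1 (0.31 log units; beyond the scatter) is the only measured effect of this kind of change. Compound 3 `Oc1ccc2ccccc2c1C(Nc1nc2ccc(Cl)cc2s1)c1cn(-c2ccccc2)nc1-c1ccccc1` differs from compound 2 by chloro in place of methoxy on an aromatic carbon; in this assay compound 3 gives 36300 nM, and the step of a 1.1-fold lower number from compound 2 to compound 3 (0.05 log units; within the scatter) is small. Compound 4 `Oc1ccc2ccccc2c1C(Nc1nc2ccc(Cl)cc2s1)c1cn(-c2ccccc2)nc1-c1ccc(I)cc1` is not yet measured; it differs from compound 3 by iodo in place of hydrogen on an aromatic carbon. This is the same kind of change as that from compound 2 to compound 1, but not the same: in compound 1 the iodo sits meta to a large group, in compound 4 para to a large group. The expected step is a 1.8-fold lower number from compound 3 to compound 4 (0.26 log units; within the scatter), resting on compound 1 and its step of a 2.0-fold lower number from compound 2 to compound 1 (0.31 log units; beyond the scatter), which rules on the two cores being equivalent rest on the small step from compound 2 to compound 3. Compound 4 is expected to give about 20000 nM, between 9000 nM and 40000 nM.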

Compound 4, half-maximal inhibitory concentration: 65000 nM
The estimate for compound 4 lay 3.3-fold (0.51 log units) below the measured number; measured number outside the range, above it.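

In this assay the iodo change reads a 1.8-fold higher number from compound 3 to compound 4 (0.25 log units; within the scatter), so the modest gain seen on the core of compound 2 does not carry over to the core of compound 3. Carrying this change between the two cores is therefore not reliable here: the same change on two cores in this assay, a 2.0-fold lower number (0.31 log units; beyond the scatter) from compound 2 to compound 1 and a 1.8-fold higher number (0.25 log units; within the scatter) from compound 3 to compound 4, 3.7-fold (0.56 log units) apart, beyond the scatter of two such steps

This does not show what separates the two steps, since the core and the position of the iodo both differ between compound 1 and compound 4, and each step rests on one pair. Open, going by these compounds, is how 4-iodophenyl behaves on the core of compound 2, and how the iodo placement of compound 1 behaves on the core of compound 3. Also open, on these data alone, is whether an amine or a carboxylic acid on that phenyl would move the number at all.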